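A few compounds are considered here, and "the series" means these few. Any claim that something is new, unique, unknown or untested is made for them only; others in the source may bear on it.

Compound 1 `Nc1nc2c(c(-c3ccccc3)cn2[C@@H]2O[C@H](CO)[C@@H](O)[C@H]2O)c(=O)[nH]1` — > 20000 nM
Compound 2 `CNc1ncnc2c1c(-c1ccsc1)cn2[C@@H]1O[C@H](CO)[C@@H](O)[C@H]1O` — > 20000 nM
Compound 3 `Cc1ncnc2c1c(-c1ccoc1)cn2[C@@H]1O[C@H](CO)[C@@H](O)[C@H]1O` — > 20000 nM

Three compounds have been run in a functional assay on K562 cells (Homo sapiens), read by MTT assay, with a stated time of 72 h; on this read-out lower numbers stand for stronger inhibition and higher numbers for weaker inhibition. For compound 1 the figure > 20000 nM is a limit of the assay, not a number. Compound 2 likewise returns only a limit, > 20000 nM. Compound 3 also stops at a limit, > 20000 nM. Where compound 1 stands among the numbers shown is therefore no more than this: the limit of > 20000 nM in this assay, at which 3 of the 3 values shown sit. Going by the values given here, nothing separates compound 1 from compound 2 or compound 3, and no step between any two of them can be measured.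

Compound 4 `Nc1nc2c(c(-c3cc4ccccc4o3)cn2[C@@H]2O[C@H](CO)[C@@H](O)[C@H]2O)c(=O)[nH]1` has not yet been tested in this assay. It differs from compound 1 in one place: 1-benzofuran-2-yl in place of phenyl on an aromatic carbon. Among the compounds with values here, the shared core carries a different aromatic group in each of compound 1, compound 2 and compound 3, and every one of them sits at the limit, so no measured step offers a guide to what this change might do.

The step that the limit leaves unreadable from compound 1 to compound 4 is expected to be essentially none beyond the scatter, with a real chance that this assay again reports only a limit. Compound 4 is accordingly estimated at 25000 nM, within a range from 6000 nM to 80000 nM.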

Compound 4, half-maximal inhibitory concentration: > 20000 nM
Compound 4 gave a limit, no number; the forecaster's own chance of this, stated with the estimate: 70%; the middle value lies beyond the limit too.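

In this assay compound 4 returns only a limit, as compound 1 does, so the step between compound 1 and compound 4 cannot be read. All the compounds shown stand together: the limit of > 20000 nM in this assay, at which 4 of the 4 values shown sit. The compounds shown leave open whether any aromatic group on the shared core gives a true number in this assay.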